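The source may hold more compounds than are shown below. What is called first, only, known or untested is meant among the compounds shown, and "the series" means these compounds.

In a functional assay on SGC-7901 cells (Homo sapiens) for cytotoxicity, read by MTT assay, with a stated time of 48 h (a lower number here means a stronger inhibitor, a higher number a weaker inhibitor), compound 1 (`CC1=NN(C(=O)CSc2ccccc2)[C@@H](c2cc(Br)cc(Br)c2O)C1`) gives 24100 nM as its half-maximal inhibitory concentration. Among the compounds with values here, that is the highest number of the three compounds measured so far, which makes it the weakest inhibitor among them. Compound 2 (`O=C(CSc1ccc([N+](=O)[O-])cc1)N1N=C(c2cc3ccccc3oc2=O)C[C@@H]1c1ccccc1C(F)(F)F`) gives 9770 nM and compound 3 (`CCCCSCC(=O)N1N=C(c2cc3ccccc3oc2=O)C[C@@H]1c1ccccc1`) gives 7300 nM in the same test. Both lie lower than compound 1 by more than the usual scatter, but each differs from it in several places, so neither shows what a single change does.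

Compound 4 (`CC1=NN(C(=O)CSc2nc3ccccc3s2)[C@@H](c2cc(Br)cc(Br)c2O)C1`) keeps the core of compound 1 and carries one change (1,3-benzothiazol-2-yl in place of phenyl on a sulfur): 1,3-benzothiazol-2-yl in place of phenyl on a sulfur. Within the data shown here, no measured pair tests this change directly, so any forecast is rough. Compound 1 sits at the top of the measured numbers, so a modest step towards a lower number is expected, and a step within the scatter would be no surprise. The expected move is a 2.0-fold lower number from compound 1 to compound 4 (0.30 log units; within the scatter) in this assay as a rough estimate. Compound 4 is estimated at 12000 nM with an expected range of 4000 nM to 30000 nM for the measurement.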

Compound 4, half-maximal inhibitory concentration: 12300 nM
Estimate against measurement, compound 4: 1.0-fold (0.01 log units) below, within the range that was stated.
By their numbers in this assay, from the lowest: compounds 3, 2, 4 and 1 (each within the scatter of the next, the first and the last beyond it).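

Within the data shown here, the swap of phenyl for 1,3-benzothiazol-2-yl on a sulfur gives the first comparison here that changes one place only, and in this assay it reads a 2.0-fold lower number from compound 1 to compound 4 (0.29 log units; within the scatter). Among these compounds, this sulfur therefore carries either the single carbon ring of compound 1 or the two-ring group of compound 4, with its two hydrogen-bond acceptors, and this test cannot tell the pair apart. Nothing available here speaks to the reason for this result.

Going by these compounds, whether an amine or a carboxylic acid on the same sulfur would shift the number beyond the scatter remains open. So does whether the same swap would read the same way on the different core shared by compound 2 and compound 3.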